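Lung exposure after oral dosing: methoxy to phenyl on amide nitrogen

The source may hold more compounds than are shown below. What is called first, only, known or untested is meant among the compounds shown, and "the series" means these compounds.

Measured compounds:
- compound 1, `CONC(=O)c1cccc(Oc2cc(CN)cc(C(F)(F)F)n2)c1`: 8780 nM
- compound 2, `NCc1cc(O[C@H]2CCCN(C(=O)Nc3ccccc3)C2)nc(C(F)(F)F)c1`: 30000 nM

Two compounds of this series have been run in an ADME assay on the whole organism (lung, Mus musculus) for pharmacokinetics, read by LC-MS, at a dose of 30 mg/kg by the oral route; on this read-out lower numbers stand for lower exposure and higher numbers for higher exposure at the dose given. Compound 1 stands at the lower of the two numbers; compound 2, which carries a phenylcarbamoyl unit on a different core, gives 30000 nM, a gap beyond the scatter. For the measured compounds named here, the two cores differ in more than one place, so no single step between them can be read.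

Compound 3, `NCc1cc(Oc2cccc(C(=O)Nc3ccccc3)c2)nc(C(F)(F)F)c1`, is the nearest analogue of compound 1 that remains unmeasured. It differs by phenyl in place of methoxy on an amide-type nitrogen, which turns the methoxycarbamoyl of compound 1 into a phenylcarbamoyl.

Going by the values given here, with no measured step of this kind on the shared core, the expected direction is open; the change is expected to stay within or near the scatter, so the step of a 1.1-fold higher number from compound 1 to compound 3 (0.06 log units; within the scatter) is estimated as small. For compound 3 the maximal plasma concentration is expected at about 10000 nM, with a range from 3500 nM to 30000 nM.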

Compound 3, maximal plasma concentration: 10300 nM
Beside the measured number, compound 3's estimate is 1.0-fold (0.01 log units) below it; the measured number falls inside the stated range.
By their numbers in this assay, from the lowest: compounds 1 and 3 (each within the scatter of the next); then compound 2.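

The amide-type nitrogen of the shared core now has its first readable step in this assay: phenyl in place of methoxy gives a 1.2-fold higher number from compound 1 to compound 3 (0.07 log units; within the scatter), so the two compounds do not separate on this read-out. At this position, then, a six-membered aromatic ring of carbon only can stand where a methoxy stood, with no ring before, and the maximal plasma concentration stays within the scatter; this rests on a single pair and says nothing about other groups at the same place. No measurement in hand bears on why the two compounds read alike.

Open, on these data alone, is whether another group on this nitrogen, such as a short chain carrying an amine, a chain ending in a carboxylic acid, or a phenyl with a fluorine on it, would give a number beyond the scatter from that of compound 1. As far as these compounds go, compound 2 differs from compound 1 and compound 3 in more than one place, so its steps to them cannot be read, and what in its structure goes with its number remains open.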